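Rearranging the chromone-type arm on a shared core

The source may report more compounds than this note shows. Statements on the series, on what has been measured and on what is new or still open speak of the compounds shown alone.

Compound 1 `Cc1cc(C)n2nc(SCc3nnc(SCc4coc5ccccc5c4=O)n3N)nc2n1`: in a functional assay on HeLa cells (Homo sapiens) for cytotoxicity, read by MTT assay, with a stated time of 72 h (on this read-out higher numbers stand for weaker inhibition and lower numbers for stronger inhibition), compound 1 gives > 25000 nM, which is a limit of the assay.
Compound 2 `Cc1cc(C)n2nc(SCc3nnc(SCc4coc5ccccc5c4=O)n3-c3ccccc3)nc2n1`: in this assay compound 2 gives > 25000 nM, again a limit of the assay.

Going by the values given here, compound 2 therefore stands only at a limit, not at a number, and the one measured step, a step that the two limits leave unreadable from compound 1 to compound 2 (phenyl in place of amino on an aromatic nitrogen), cannot be read since both values sit at the limit of > 25000 nM in this assay, at which 2 of the 2 values shown sit.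

Compound 3 `Cc1cc(C)n2nc(SCc3nnc(SCc4cc(=O)c5ccccc5o4)n3-c3ccccc3)nc2n1` has the same atoms as compound 2, joined differently: a group of 11 heavy atoms (9 carbon, 2 oxygen; one six-membered aromatic ring of carbon only, one six-membered aromatic ring with 1 hetero atom) in place of a group of 11 heavy atoms (9 carbon, 2 oxygen; one six-membered aromatic ring of carbon only, one six-membered aromatic ring with 1 hetero atom), on a saturated chain carbon bound to a sulfur. Among the compounds with values here, no measured step bears on this change, and the single step between compound 1 and compound 2 gives no size at all. The expectation for this assay is therefore no step beyond the scatter, with the likely outcome being another limit. Compound 3 is expected to give about 40000 nM, within 12000 nM to 150000 nM. The step this estimate implies, a step that the limit leaves unreadable from compound 2 to compound 3, is expected to be essentially nil.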

Compound 3, half-maximal inhibitory concentration: > 25000 nM
Compound 3: a limit, no number (the forecaster's own chance of this, stated with the estimate: 75%); the middle value does not contradict the limit.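

The step between compound 2 and compound 3 cannot be read, since in this assay both stand at a limit and not at a number: the limit of > 25000 nM in this assay, at which 3 of the 3 values shown sit.

The compounds shown leave open how strongly any of the three inhibits, and whether either change on the shared core makes any difference.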